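A few compounds are considered here, and "the series" means these few. Any claim that something is new, unique, unknown or untested is made for them only; others in the source may bear on it.

Among the compounds with values here, compound 1 `CO[C@@H]1C[C@@H]2[C@H]([C@]1(N)C(=O)O)[C@@]2(F)C(=O)O` gives 39.2 nM in a binding assay on CHO cells for binding affinity to metabotropic glutamate receptor 2 (Rattus norvegicus) (on this read-out lower numbers stand for stronger inhibition and higher numbers for weaker inhibition), the highest of the two numbers measured so far; its nearest neighbour, compound 2 `N[C@]1(C(=O)O)[C@H]2[C@@H](C[C@H]1OCc1cc(Cl)cc(Cl)c1)[C@]2(F)C(=O)O`, gives 5.61 nM. Within the data shown here, the single measured step, a 7.0-fold lower number from compound 1 to compound 2 (0.84 log units; beyond the scatter), came from placing 3,5-dichlorophenyl in place of hydrogen on a saturated chain carbon bound to an oxygen on a saturated carbon. Compound 3 `N[C@]1(C(=O)O)[C@H]2[C@@H](C[C@H]1OCc1ccc(Cl)cc1Cl)[C@]2(F)C(=O)O` differs from compound 1 by 2,4-dichlorophenyl in place of hydrogen on a saturated chain carbon bound to an oxygen on a saturated carbon. Because that one step was a 7.0-fold lower number from compound 1 to compound 2 (0.84 log units; beyond the scatter), a step of similar size and direction is expected here, a 4.9-fold lower number from compound 1 to compound 3 (0.69 log units; beyond the scatter). Compound 3 is therefore estimated at 8 nM, between 3 nM and 25 nM.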

Compound 3, inhibition constant: 3.89 nM
Estimate against measurement, compound 3: 2.1-fold (0.31 log units) above, and the stated range covers the measured number.
By their numbers in this assay, from the lowest: compounds 3 and 2 (each within the scatter of the next); then compound 1.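

Placed on the saturated chain carbon bound to the oxygen, 2,4-dichlorophenyl also gives a step beyond the scatter (a 10-fold lower number from compound 1 to compound 3 (1.00 log units; beyond the scatter)), so the lower number seen with compound 2 is not tied to a single arrangement of the two chlorines. The two arrangements cannot be told apart in this binding assay (a 1.4-fold lower number from compound 2 to compound 3 (0.16 log units; within the scatter)), as that step lies within the scatter. Nothing available explains these results.

Still open, as far as these compounds go, is whether the chlorines matter at all, which a plain phenyl would test. From the compounds shown here alone, what a trifluoromethyl-substituted phenyl or a longer chain carrying the ring would give also remains unknown.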